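A few compounds are considered here, and "the series" means these few. Any claim that something is new, unique, unknown or untested is made for them only; others in the source may bear on it.

Measured so far:
- compound 1 `O=C(CN(c1ncnc2c1ncn2C1CCCCO1)C1CC1)N[C@@H](CCC(=O)OCc1ccccc1)C(=O)OCc1ccccc1`: 32.6%
- compound 2 `N=C(N)NCCC[C@H](NC(=O)CN(c1nc(Cl)nc2[nH]cnc12)C1CC1)C(=O)OCc1ccccc1`: 23.2%

In a functional assay on the whole organism (Tail, strain ICR) with Mus musculus as the target, in the tail flick test, with a stated time of 30 min, at a dose of 25 umol/kg by the oral route (a lower number here means a weaker effect, a higher number a stronger effect of the compound at the dose given), compound 1 gives 32.6%. Of the two numbers shown, compound 1 has the larger figure, but compound 2, which gives 23.2%, lies within the usual scatter of compound 1, so the two cannot be ranked against each other.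

Compound 3 `CC(C)C[C@H](NC(=O)CN(c1ncnc2c1ncn2C1CCCCO1)C1CC1)C(=O)OCc1ccccc1` has not yet been measured. It differs from compound 1 in one place: isopropyl in place of (benzyloxycarbonyl)methyl on a saturated chain carbon, two bonds along the chain from an amide-type nitrogen and a carbonyl carbon. Among the measured compounds shown here, no step between two measured compounds has been recorded, so the numbers so far say nothing about how a change of this kind acts, and compound 2 differs from compound 1 in more than one place.

Without such a step, the expected change from compound 1 to compound 3 is set at a number 2.6 percentage points lower from compound 1 to compound 3 (within the scatter), no more than the scatter. On that basis compound 3 is estimated at 30%, with a range from 10% to 55%.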

Compound 3, a percentage reported as activity, at one dose (the size of the read-out at that dose, not a potency): 26.2%
Estimate against measurement, compound 3: 3.8 percentage points above, and the stated range covers the measured number.
By their numbers in this assay, from the lowest: compounds 2, 3 and 1 (each within the scatter of the next).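

In this assay, among the compounds shown here, putting isopropyl in place of (benzyloxycarbonyl)methyl gives a number 6.4 percentage points lower from compound 1 to compound 3 (within the scatter), the first step that changes only one place. On a saturated chain carbon, two bonds along the chain from an amide-type nitrogen and a carbonyl carbon, this much smaller group, with no ring, gives a read-out that cannot be told apart from that of the larger group, so this pair shows no need for the six-membered aromatic ring of carbon only at this place. No separate measurement of any property of these groups accompanies this result.

From the compounds shown here alone, it remains open whether a free carboxylic acid, an amine or a longer unbranched alkyl chain at this place would go beyond the scatter. A single dose also leaves open whether the two compounds would still match at other doses.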